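A few compounds are considered here, and "the series" means these few. Any claim that something is new, unique, unknown or untested is made for them only; others in the source may bear on it.

Measured so far in a functional assay on PC-3 cells (Homo sapiens) for antiproliferative activity, read by MTT assay, with a stated time of 72 h; a lower number here means a stronger inhibitor, a higher number a weaker inhibitor:
Compound 1 `C/C(=N\NC(=O)c1cccc(S(=O)(=O)N2CCOCC2)c1)c1cccc(N)c1` gives > 100000 nM, which is a limit of the assay rather than a number.
Compound 2 `C/C(=N\NC(=O)c1cccc(S(=O)(=O)N2CCOCC2)c1)c1ccc(O)cc1` gives 36200 nM.
Compound 3 `C/C(=N\NC(=O)c1cccc(S(=O)(=O)N2CCOCC2)c1)c1cc(Br)ccc1O` gives 6890 nM.

Compound 3 holds the lowest of the two plain numbers, with compound 2 next a 5.3-fold lower number from compound 2 to compound 3 (0.72 log units; beyond the scatter). Compound 4 `C/C(=N\NC(=O)c1cccc(S(=O)(=O)N2CCOCC2)c1)c1cccc(N)c1O` differs from compound 3 in one place: 3-amino-2-hydroxyphenyl in place of 5-bromo-2-hydroxyphenyl on a carbon with a double bond to nitrogen. Within the data shown here, no measured step swaps bromine for an amino group directly. Among the measured compounds shown here, the steps that bear on it are an at least 14-fold lower number from compound 1 to compound 3 (1.16 log units; beyond the scatter) and a 5.3-fold lower number from compound 2 to compound 3 (0.72 log units; beyond the scatter), both pointing to the 5-bromo-2-hydroxyphenyl of compound 3 as the strongest of the three, whereas the 3-aminophenyl of compound 1 sits at the limit (the limit of > 100000 nM in this assay, at which 1 of the 3 values shown sits). Since compound 4 gives up the bromine and takes on an amino group, a modest rise in number is expected a 4.4-fold higher number from compound 3 to compound 4 (0.64 log units; beyond the scatter). Compound 4 is estimated at 30000 nM, within 8000 nM to 110000 nM.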

Compound 4, half-maximal inhibitory concentration: 2330 nM
For compound 4 the middle estimate is 13-fold (1.11 log units) above the measured one, outside the stated range (below it).
By their numbers in this assay, from the lowest: compound 4; then compound 3; then compound 2. At a limit, above all of these: compound 1.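

In this assay, an amino group on this ring does not rule out activity: swapping the 5-bromo-2-hydroxyphenyl for 3-amino-2-hydroxyphenyl gives a 3.0-fold lower number from compound 3 to compound 4 (0.47 log units; beyond the scatter), and replacing the 4-hydroxyphenyl gives a 16-fold lower number from compound 2 to compound 4 (1.19 log units; beyond the scatter). Compound 1 gives a limit rather than a number: the limit of > 100000 nM in this assay, at which 1 of the 4 values shown sits. With the amino group kept, hydroxy in place of hydrogen on an aromatic carbon gives an at least 42-fold lower number from compound 1 to compound 4 (1.63 log units; beyond the scatter), so this single added group turns a compound at the limit into the lowest number shown.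

Still open, going by these compounds, is whether a methoxy group could stand in for that hydroxy. Also open, on these data alone, is whether an acetamide could replace the amino group and keep this number.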